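Following one carbonyl swap in a lipophilicity series

The source may report more compounds than this note shows. Statements on the series, on what has been measured and on what is new or still open speak of the compounds shown alone.

Compound 1 `CCOC(=O)N1CCC(NC(=O)Nc2ccc(OC(F)(F)F)c(F)c2)CC1` gives 5.94
Compound 2 `CC(C)C(=O)N1CCC(NC(=O)Nc2ccc(C(F)(F)F)c(F)c2)CC1` gives 4.4
Compound 3 `CCOC(=O)N1CCC(NC(=O)Nc2ccc(C(F)(F)F)c(F)c2)CC1` gives 5.46

In a physicochemical assay for lipophilicity, read by HPLC, with a stated time of 90 min, tested at 100 uM (a higher number here means a more lipophilic compound, a lower number a more polar compound), compound 3 stands second highest of the three, below compound 1 and above compound 2. Compound 4 `O=C(Nc1ccc(C(F)(F)F)c(F)c1)NC1CCN(C(=O)[C@@H]2CCOC2)CC1` changes one group (oxolan-3-yl in place of ethoxy on a carbonyl carbon), with oxolan-3-yl in place of ethoxy on a carbonyl carbon. The closest measured change is ethoxy in place of isopropyl on a carbonyl carbon (a number 1.06 log units higher from compound 2 to compound 3 (beyond the scatter)). Trifluoromethyl in place of trifluoromethoxy (a number 0.48 log units lower from compound 1 to compound 3 (beyond the scatter)) concerns a different place and bears less on this change. Compound 4, like compound 2 (4.4), has no ethoxy on that carbonyl carbon. Among the compounds with values here, no measurement yet covers oxolan-3-yl itself. A large step downward is therefore expected (a number 1.46 log units lower from compound 3 to compound 4 (beyond the scatter)). Compound 4 is estimated at 4 (expected range 3.4 to 4.6).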

Compound 4, partition coefficient: 3.41
Estimate against measurement, compound 4: 0.59 log units above, and the stated range covers the measured number.
By their numbers in this assay, from the lowest: compound 4; then compound 2; then compound 3; then compound 1.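

In this assay, oxolan-3-yl in place of ethoxy on this carbonyl carbon gives a number 2.05 log units lower from compound 3 to compound 4 (beyond the scatter) as its step, and oxolan-3-yl in place of isopropyl gives a number 0.99 log units lower from compound 2 to compound 4 (beyond the scatter) as a further one. Groups at this one place therefore spread widely, and losing ethoxy does not fix the number at a single level, since the two replacements end up apart. Nothing available explains the size of these steps. The compounds shown leave open where cyclopentyl, a five-membered ring without the oxygen, would fall, and how the opposite stereoisomer of oxolan-3-yl would read.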